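The source may report more compounds than this note shows. Statements on the series, on what has been measured and on what is new or still open speak of the compounds shown alone.

Compound 2 `O=c1cc(N2CCN(CC3CCC(OS(=O)(=O)c4ccc5c(c4)CCO5)CC3)CC2)sc2c([N+](=O)[O-])cc(C(F)(F)F)cc12` differs from compound 1 `Cc1ccc(C(=O)OC2CCC(CN3CCN(c4cc(=O)c5cc(C(F)(F)F)cc([N+](=O)[O-])c5s4)CC3)CC2)cc1` only in the group on an oxygen on a saturated carbon. In an ADME assay on Vero cells (Chlorocebus sabaeus) for cytotoxicity, read by MTT assay, with a stated time of 48 h (on this read-out lower numbers stand for stronger inhibition and higher numbers for weaker inhibition), compound 1 gives > 64 ug/mL, which is a limit and not a number. Compound 2 gives > 64 ug/mL, likewise a limit. Compound 2 thus sits at the limit of > 64 ug/mL in this assay, at which 2 of the 2 values shown sit, with no numerical value yet shown for either compound. Compound 3 `COc1cccc(C(=O)OC2CCC(CN3CCN(c4cc(=O)c5cc(C(F)(F)F)cc([N+](=O)[O-])c5s4)CC3)CC2)c1` follows with one change, (a group of 10 heavy atoms (8 carbon, 2 oxygen; one six-membered aromatic ring of carbon only) in place of a group of 12 heavy atoms (8 carbon, 3 oxygen, 1 sulfur; one five-membered non-aromatic ring with 1 hetero atom, one six-membered aromatic ring of carbon only), on an oxygen on a saturated carbon). For the measured compounds named here, the only measured step that bears on it, a step that the two limits leave unreadable from compound 1 to compound 2, has no readable size, although it also exchanged a group at that same place and both compounds remained at the limit. In this assay no step beyond the scatter is therefore expected, and no direction can be favoured. The expected step is a step that the limit leaves unreadable from compound 2 to compound 3. For compound 3 the estimate is 70 ug/mL, with an expected range from 40 ug/mL to 128 ug/mL.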

Compound 3, half-maximal inhibitory concentration: > 64 ug/mL
Compound 3: no number, only a limit; the forecaster's own chance of this, stated with the estimate: 85%; the middle value does not contradict the limit.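

In this assay compound 3 gives > 64 ug/mL, a limit and not a number, so its steps from compound 1 and compound 2 cannot be read. The compounds shown leave open whether changing the group on that oxygen alters the read-out at all: the limit of > 64 ug/mL in this assay, at which 3 of the 3 values shown sit.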